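The source may report more compounds than this note shows. Statements on the series, on what has been measured and on what is new or still open speak of the compounds shown alone.

In a functional assay on HepG2 cells (Homo sapiens) for cytotoxicity, read by MTT assay, with a stated time of 48 h (a higher number here means a weaker inhibitor, a lower number a stronger inhibitor), compound 1 `CCCc1nnc(SCC(=O)c2ccc(C)cc2)n1N1C(=O)c2ccccc2C1=O` gives > 200000 nM, which is a limit of the assay rather than a number. Compound 2 `CCCc1nnc(SCc2ccccc2Cl)n1N1C(=O)c2ccccc2C1=O` likewise gives in this assay > 200000 nM, again a limit and not a number. The step that the two limits leave unreadable from compound 1 to compound 2 therefore cannot be read, since (the limit of > 200000 nM in this assay, at which 2 of the 2 values shown sit). Compound 2 thus stands at the limit of this assay, and nothing shown places it on a numerical scale.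

Compound 3 `COc1cc(-c2nnc(SCc3ccccc3Cl)n2N2C(=O)c3ccccc3C2=O)cc(OC)c1OC` differs from compound 2 by 3,4,5-trimethoxyphenyl in place of propyl on an aromatic carbon. No measured step touches this change: the only step shown, a step that the two limits leave unreadable from compound 1 to compound 2, is itself unreadable, and the limit of > 200000 nM in this assay, at which 2 of the 2 values shown sit, is the whole of what the two measured compounds tell. There is accordingly no ground to expect compound 3 to move off the limit in this assay, and no ground to expect a particular size of step in either direction. Compound 3 is expected to give about 250000 nM in this assay, within the range 100000 nM to 1000000 nM, and most probably to be reported again only as a limit. This estimate means a step that the limit leaves unreadable from compound 2 to compound 3.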

Compound 3, half-maximal inhibitory concentration: > 200000 nM
Compound 3 was reported as a limit (the forecaster's own chance of this, stated with the estimate: 70%); the middle value lies beyond the limit too.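

In this assay compound 3 gives > 200000 nM, which is a limit of the assay and not a number, so the step from compound 2 to compound 3 cannot be read. The compounds shown leave open whether any change to the shared core would bring a numerical value in this assay: the limit of > 200000 nM in this assay, at which 3 of the 3 values shown sit.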